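Removing the Oxetane Ether: Cytotoxicity of a Hydroxy Analogue

This account rests on a few compounds, and the source may have more. Where it says the series, first, only, none or still open, it means among the compounds named here.

Compound 1 `CC(C)(C)C#Cc1cc(N(C(=O)[C@H]2CC[C@H](C)CC2)[C@H]2CC[C@H](OC3COC3)CC2)c(C(=O)O)s1` — > 20000 nM
Compound 2 `CC(C)(C)C#Cc1cc(N(C(=O)[C@H]2CC[C@H](C)CC2)[C@H]2CC[C@@H](Oc3cccnc3)CC2)c(C(=O)O)s1` — > 20000 nM
Compound 3 `CC1=CC[C@H](C(=O)N(c2cc(C#CC(C)(C)C)sc2C(=O)O)[C@H]2CC[C@](O)(CO[C@H]3CCOC3)CC2)CC1` — > 20000 nM

Of the compounds shown here, three sharing the same core have been tested in an ADME assay on MT4 cells (Homo sapiens) for cytotoxicity, with a stated time of 5 days; on this read-out higher numbers stand for lower toxicity in this test and lower numbers for higher toxicity in this test. Compound 1 gives > 20000 nM, which is a limit of the assay and not a measured number. Compound 2 likewise sits at a limit, > 20000 nM. Compound 3 also reaches only a limit, > 20000 nM. So compound 1 stands where the other two stand: at the limit of > 20000 nM in this assay, at which 3 of the 3 values shown sit. Within the data shown here, no step between two measured compounds can be read from these numbers, since none of them is a true value.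

Compound 4 `CC(C)(C)C#Cc1cc(N(C(=O)[C@H]2CC[C@H](C)CC2)[C@H]2CC[C@H](O)CC2)c(C(=O)O)s1` has not yet been measured in this assay. It differs from compound 1 as follows: hydrogen in place of oxetan-3-yl on an oxygen on a saturated carbon. The change is small in size and leaves the rest of the molecule untouched.

With all three measured compounds at the limit, nothing suggests that compound 4 should behave otherwise. The step that the limit leaves unreadable from compound 1 to compound 4 is expected to be none beyond the scatter. Compound 4 is therefore estimated to give 30000 nM in this assay, with a range from 15000 nM to 60000 nM, and most likely only a limit will again be reported.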

Compound 4, half-maximal cytotoxic concentration: > 20000 nM
Compound 4: only a limit was reported; the forecaster's own chance of this, stated with the estimate: 85%; the middle value lies beyond the limit too.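

In this assay compound 4 gives > 20000 nM and this is a limit of the assay, not a number. Among these compounds, compound 1 also sits at a limit, so no step from compound 1 to compound 4 can be read: the limit of > 20000 nM in this assay, at which 4 of the 4 values shown sit. For all the compounds shown, the concentration at which each would turn toxic in this assay remains open.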